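Moving the chlorine around the phenoxy ring

The source may hold more compounds than are shown below. What is called first, only, known or untested is meant among the compounds shown, and "the series" means these compounds.

Compound 1 `CNC(=O)c1cccc(Cn2nc(C)c(NC(=O)c3ccc(COc4ccc(OC)cc4)cc3)c2C)c1`: in a functional assay on MIA PaCa-2 cells (Homo sapiens) for antiproliferative activity, read by MTT assay, with a stated time of 72 h (on this read-out lower numbers stand for an effect already at smaller amounts and higher numbers for an effect only at larger amounts of compound), compound 1 gives 8000 nM.
Compound 2 `CNC(=O)c1cccc(Cn2nc(C)c(NC(=O)c3ccc(COc4ccccc4Cl)cc3)c2C)c1`: in this assay compound 2 gives 6300 nM.

Going by the values given here, compound 2 stands at the lowest of the two numbers measured so far, with compound 1 its only neighbour, and the step of a 1.3-fold lower number from compound 1 to compound 2 (0.10 log units; within the scatter) lies within the scatter. Compound 3 `CNC(=O)c1cccc(Cn2nc(C)c(NC(=O)c3ccc(COc4cccc(Cl)c4)cc3)c2C)c1` differs from compound 2 in one place: 3-chlorophenyl in place of 2-chlorophenyl on an oxygen on a saturated carbon. Among the compounds with values here, no measured step moves the chlorine from one place on this ring to another; the single measured step exchanges the whole substituted ring and is within the scatter. Within the data shown here, that step is the only guide, and it suggests the ring on this oxygen tolerates variation without a shift beyond the scatter. Compound 3 is therefore expected to show a step of about a 1.1-fold lower number from compound 2 to compound 3 (0.02 log units; within the scatter) in this assay, that is, no movement beyond the scatter. The estimate for compound 3 is 6000 nM, with a range from 2500 nM to 15000 nM.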

Compound 3, half-maximal effective concentration: 5900 nM
The estimate for compound 3 lay 1.0-fold (0.01 log units) above the measured number; the range from low to high includes it.
By their numbers in this assay, from the lowest: compounds 3, 2 and 1 (each within the scatter of the next).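

Going by these compounds alone, a step of a 1.1-fold lower number from compound 2 to compound 3 (0.03 log units; within the scatter) in this assay is the first reading of the chlorine's place on this ring, and it shows that 3-chlorophenyl and 2-chlorophenyl on an oxygen on a saturated carbon cannot be told apart here. The earlier step exchanged the whole substituted ring, and a second such exchange, a step of a 1.4-fold lower number from compound 1 to compound 3 (0.13 log units; within the scatter) and also within the scatter, shows that 3-chlorophenyl and 4-methoxyphenyl cannot be told apart either. All three compounds thus lie within the scatter of one another, so this position has so far given no difference that can be read. Nothing measured here says why these numbers lie so close. The compounds shown leave open whether 4-chlorophenyl, a phenyl ring carrying an amine or a carboxylic acid, or a longer chain on this oxygen would give a step beyond the scatter.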